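Cytotoxicity notes: hydroxymethyl, nitro, bromo and a nitrile

A few compounds are considered here, and "the series" means these few. Any claim that something is new, unique, unknown or untested is made for them only; others in the source may bear on it.

Compound 1 `COc1cc(CC(O)c2ccc(-c3ccc([N+](=O)[O-])cc3)cc2)c([N+](=O)[O-])cc1OC` gives 21000 nM in an ADME assay on HeLa Rh cells (Homo sapiens) for cytotoxicity, read by microscopy; a higher number here means that more compound is tolerated, a lower number that less compound is tolerated.
Compound 2 `COc1cc(CC(O)c2ccc(-c3ccc(CO)cc3)cc2)c([N+](=O)[O-])cc1OC` gives > 244000 nM in this assay.
Compound 3 `COc1cc(CC(O)c2ccc(-c3ccc(Br)cc3)cc2)c([N+](=O)[O-])cc1OC` gives 4300 nM in this assay.

Compound 2 stands at the top of the series: its value is a limit of this assay, not a number, and compound 2 sits at the limit of > 244000 nM in this assay, at which 1 of the 3 values shown sits. Compound 4 `COc1cc(CC(O)c2ccc(-c3cccc(C#N)c3)cc2)c([N+](=O)[O-])cc1OC` brings the change (3-cyanophenyl in place of 4-(hydroxymethyl)phenyl on an aromatic carbon). Among the compounds with values here, two measured steps bear on it. From compound 1 to compound 2 the step is an at least 11-fold higher number from compound 1 to compound 2 (1.06 log units; beyond the scatter), and from compound 2 to compound 3 it is an at least 56-fold lower number from compound 2 to compound 3 (1.75 log units; beyond the scatter); both replacements of the hydroxymethyl-bearing end lead to markedly lower numbers. A nitrile is neither nitro nor bromo, yet both measured swaps away from hydroxymethyl went the same way, so a clearly lower number is expected for compound 4, of a size near an at least 12-fold lower number from compound 2 to compound 4 (1.08 log units; beyond the scatter). Compound 4 is estimated at 20000 nM, with a plausible range from 5000 nM to 120000 nM.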

Compound 4, half-maximal cytotoxic concentration: 5200 nM
Beside the measured number, compound 4's estimate is 3.8-fold (0.59 log units) above it, within the range that was stated.
By their numbers in this assay, from the lowest: compounds 3 and 4 (each within the scatter of the next); then compound 1. At a limit, above all of these: compound 2.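

In this assay, 3-cyanophenyl joins the other replacements of 4-(hydroxymethyl)phenyl in giving a much lower number, an at least 46-fold lower number from compound 2 to compound 4 (1.67 log units; beyond the scatter), so all three replacements shown now go the same way at this position. The nitrile end cannot be told apart from the bromo end, a 1.2-fold higher number from compound 3 to compound 4 (0.08 log units; within the scatter), but it does differ from the nitro end, a 4.0-fold lower number from compound 1 to compound 4 (0.61 log units; beyond the scatter), so these replacements do not all give the same result. Compound 2 remains a limit of the assay and not a number: the limit of > 244000 nM in this assay, at which 1 of the 4 values shown sits.

The compounds shown do not separate the contribution of the nitrile from that of its place on the ring. On these data alone, whether the higher number is particular to hydroxymethyl stays open, and a carboxylic acid, an aminomethyl group or a longer hydroxyalkyl chain at this place would bear on that question.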